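The source may hold more compounds than are shown below. What is called first, only, known or untested is meant among the compounds shown, and "the series" means these compounds.

Measured so far in this series:

compound 1 `O=c1[nH]cc(S(=O)(=O)Nc2cccc(-c3cn(-c4cccc(F)c4)nn3)c2)c(=O)[nH]1`: 7200 nM
compound 2 `O=c1[nH]cc(S(=O)(=O)Nc2cccc(-c3cn(-c4ccc(F)cc4)nn3)c2)c(=O)[nH]1`: > 20000 nM
compound 3 `O=c1[nH]cc(S(=O)(=O)Nc2ccc(-c3cn(-c4cccc(F)c4)nn3)cc2)c(=O)[nH]1`: 9980 nM

All three have been run in a functional assay on A549 cells (Homo sapiens) for antiproliferative activity, read by MTT assay, with a stated time of 24 h; a higher number here means a weaker inhibitor, a lower number a stronger inhibitor. Compound 1 gives 7200 nM. For compound 2 the assay reports only a limit, > 20000 nM. The change from compound 1 to compound 2 is 4-fluorophenyl in place of 3-fluorophenyl on an aromatic nitrogen and it produced an at least 2.7-fold higher number from compound 1 to compound 2 (0.44 log units; beyond the scatter); the step can only be bounded because of the limit of > 20000 nM in this assay, at which 1 of the 3 values shown sits. Compound 3 gives 9980 nM, which sits within the scatter of the value for compound 1, so no order between the two is claimed. The difference between the cores of compound 1 and compound 3 is not broken down here.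

Compound 4 `O=c1[nH]cc(S(=O)(=O)Nc2ccc(-c3cn(-c4ccc(F)cc4)nn3)cc2)c(=O)[nH]1` awaits measurement. It differs from compound 3 by 4-fluorophenyl in place of 3-fluorophenyl on an aromatic nitrogen, the same change already seen between compound 1 and compound 2, at the same place. Compound 4 is therefore expected to move by a 3.0-fold higher number from compound 3 to compound 4 (0.48 log units; beyond the scatter), a step of roughly the size seen from compound 1 to compound 2 in the same direction, resting on an at least 2.7-fold higher number from compound 1 to compound 2 (0.44 log units; beyond the scatter) and on the starting value of compound 3, 9980 nM. Compound 4 is estimated at 30000 nM, between 14000 nM and 80000 nM, with a real chance that only a limit is returned.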

Compound 4, half-maximal inhibitory concentration: 9720 nM
Estimate against measurement, compound 4: 3.1-fold (0.49 log units) above; measured number outside the range, below it.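

In this assay, 4-fluorophenyl in place of 3-fluorophenyl on the aromatic nitrogen gives a 1.0-fold lower number from compound 3 to compound 4 (0.01 log units; within the scatter), so on this core the swap produces no step beyond the scatter. The swap therefore does not carry over unchanged from one core to the other: the same change on two cores in this assay, an at least 2.7-fold higher number (0.44 log units; beyond the scatter) from compound 1 to compound 2 and a 1.0-fold lower number (0.01 log units; within the scatter) from compound 3 to compound 4, at least 2.8-fold (0.45 log units) apart, beyond the scatter of two such steps. Across these four compounds, this shows a dependence on the core for this one change only, and it does not fix the true size of the gap, as compound 2 carries a limit and not a number: the limit of > 20000 nM in this assay, at which 1 of the 4 values shown sits.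

The compounds shown leave open whether a phenyl bearing a methoxy group, a nitrile or a carboxylic acid in place of fluorine would behave as on the core of compound 1 or as on the core of compound 3. Also open, from the compounds shown here alone, is whether the difference between the two cores would persist with an unsubstituted phenyl on the same aromatic nitrogen.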